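The source may hold more compounds than are shown below. What is called first, only, known or untested is meant among the compounds shown, and "the series" means these compounds.

Compound 1 `COc1cc(C(=O)C2Sc3nnc(-c4cc(OC)c(OC)c(OC)c4)n3NC2c2ccco2)cc(OC)c1OC` carries a 3,4,5-trimethoxyphenyl group on the carbonyl carbon. In a functional assay on HepG2 cells (Homo sapiens) for cytotoxicity, read by MTT assay, with a stated time of 48 h (a lower number here means a stronger inhibitor, a higher number a weaker inhibitor), compound 1 gives only a limit, > 100000 nM. Compound 2 `COc1cc(-c2nnc3n2NC(c2ccco2)C(C(=O)c2ccc(C)cc2)S3)cc(OC)c1OC` has a 4-methylphenyl group in that position, and in this assay compound 2 gives 17400 nM. Compound 3 `COc1ccc(C(=O)C2Sc3nnc(-c4cc(OC)c(OC)c(OC)c4)n3NC2c2ccco2)cc1` carries a 4-methoxyphenyl group there. In this assay compound 3 likewise gives only a limit, > 100000 nM. Compound 3 thus stands at the limit of > 100000 nM in this assay, at which 2 of the 3 values shown sit, and its place relative to compound 1 cannot be read, as the step that the two limits leave unreadable from compound 1 to compound 3 shows. The two readable steps run an at least 5.7-fold lower number from compound 1 to compound 2 (0.75 log units; beyond the scatter) and an at least 5.7-fold higher number from compound 2 to compound 3 (0.75 log units; beyond the scatter).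

Compound 4 `COc1cc(-c2nnc3n2NC(c2ccco2)C(C(=O)c2ccc(F)c(F)c2)S3)cc(OC)c1OC` has not been measured. It differs from compound 3 in one place: 3,4-difluorophenyl in place of 4-methoxyphenyl on a carbonyl carbon. For the measured compounds named here, the step most closely related is the one from compound 2 to compound 3, where the 4-methylphenyl analogue gave a number and the 4-methoxyphenyl analogue only a limit. With two of three compounds at the limit, the expected outcome is uncertain, but the 3,4-difluorophenyl group, like the 4-methylphenyl group of compound 2, carries no acceptor, so a number rather than a limit is considered plausible. Compound 4 is therefore expected to give 50000 nM, between 10000 nM and 200000 nM. This corresponds to an expected step of an at least 2.0-fold lower number from compound 3 to compound 4 (0.30 log units; that floor lies within the scatter).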

Compound 4, half-maximal inhibitory concentration: 52400 nM
Compound 4: middle estimate off by 1.0-fold (0.02 log units), on the low side; the measured number falls inside the stated range.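

In this assay, the 3,4-difluorophenyl group is the second group on the carbonyl carbon, after 4-methylphenyl, to give a number rather than a limit, and neither of the two carries a methoxy, although the steps run an at least 1.9-fold lower number from compound 3 to compound 4 (0.28 log units; that floor lies within the scatter) and an at least 1.9-fold lower number from compound 1 to compound 4 (0.28 log units; that floor lies within the scatter), so no gain beyond the scatter is established. The two groups that give numbers are not equivalent at this position, as the change runs a 3.0-fold higher number from compound 2 to compound 4 (0.48 log units; beyond the scatter). The split by methoxy holds for all the compounds shown, but compound 1 and compound 3 remain limits rather than numbers, and the step between them cannot be read: the limit of > 100000 nM in this assay, at which 2 of the 4 values shown sit.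

The compounds shown leave open how far compound 1 and compound 3 really stand from compound 4, and whether the methoxy group itself separates these results from the others. They also leave open how an unsubstituted phenyl, a single fluorine or chlorine on the phenyl ring, or a non-aromatic group such as an amine or a carboxylic acid would read on this carbonyl carbon.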